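Methoxy Substitution Carried From One Core to Another

The source may hold more compounds than are shown below. What is called first, only, known or untested is meant among the compounds shown, and "the series" means these compounds.

Compound 1 `CC/C(=C(\c1ccccc1)c1ccc(NC(=O)C(C)C)cc1)c1ccc(OCc2ccccc2)cc1` and compound 2 `CC/C(=C(/c1ccc(NC(=O)C(C)C)cc1)c1ccc(OC)cc1)c1ccc(OCc2ccccc2)cc1` share one core and differ by methoxy in place of hydrogen on an aromatic carbon. In a functional assay on HeLa cells (Homo sapiens) for inhibition, read by trypan blue exclusion, with a stated time of 72 h (on this read-out higher numbers stand for weaker inhibition of growth and lower numbers for stronger inhibition of growth), compound 1 gives 10200 nM, and compound 2 gives 4200 nM, so that this change produced a 2.4-fold lower number from compound 1 to compound 2 (0.39 log units; beyond the scatter). Compound 3 `CC/C(=C(/c1ccccc1)c1ccc(NC(=O)C(C)C)cc1)c1ccc(Cl)cc1Cl` is built on a second core; the difference between the two cores is not broken down here. In this assay compound 3 gives 8200 nM, a number that lies within the usual scatter of both compound 1 and compound 2, so no order among these three is claimed. Compound 4 `CC/C(=C(\c1ccc(NC(=O)C(C)C)cc1)c1ccc(OC)cc1)c1ccc(Cl)cc1Cl` has not yet been measured. It differs from compound 3 by methoxy in place of hydrogen on an aromatic carbon, which is the same change that led from compound 1 to compound 2, and this is the only change that occurs on both cores among the compounds shown. Because a 2.4-fold lower number from compound 1 to compound 2 (0.39 log units; beyond the scatter) was observed on the first core, a step of similar size is expected on the second core as well, though the expectation rests on a single earlier example. In this assay compound 4 is expected to give about 3500 nM, most likely between 1500 nM and 8500 nM. The expected step is a 2.3-fold lower number from compound 3 to compound 4 (0.37 log units; beyond the scatter).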

Compound 4, concentration for 50% growth inhibition: 5500 nM
Compound 4: middle estimate off by 1.6-fold (0.20 log units), on the low side; the measured number falls inside the stated range.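

On the second core, the replacement of hydrogen by methoxy appears as a 1.5-fold lower number from compound 3 to compound 4 (0.17 log units; within the scatter) in this assay, a step that cannot be told from repeat variation when taken alone. Set beside the step on the first core, it does not differ from it by more than the scatter allows: the same change on two cores in this assay, a 2.4-fold lower number (0.39 log units; beyond the scatter) from compound 1 to compound 2 and a 1.5-fold lower number (0.17 log units; within the scatter) from compound 3 to compound 4, 1.6-fold (0.21 log units) apart, within the scatter of two such steps. Among these compounds, the two results are therefore compatible with the change carrying over from one core to the other at a similar size, but they do not prove that it does; only the step on the first core stands clear of the scatter, and two pairs establish no rule for the series.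

The compounds shown leave open whether a hydroxyl, an amine or a carboxylic acid at the same place would read like methoxy in this assay. They also leave open whether a longer chain on that oxygen, such as ethoxy, would follow the same course on both cores.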